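Replacing a Cyclohexanol Substituent with an Open Hydroxyethoxy Chain

The source may hold more compounds than are shown below. What is called first, only, known or untested is meant among the compounds shown, and "the series" means these compounds.

Compound 1 `CC(O)c1cn(CCNc2nonc2/C(=N/O)Nc2ccc(F)c(Br)c2)nn1`: 362 nM
Compound 2 `O/N=C(\Nc1ccc(F)c(Br)c1)c1nonc1NCCn1cc(C2(O)CCCCC2)nn1`: 865 nM

Of the two measured compounds, compound 2 gives the highest number in an assay on isolated protein for inhibition of Indoleamine 2,3-dioxygenase 2 (Homo sapiens) (on this read-out lower numbers stand for stronger inhibition and higher numbers for weaker inhibition), with compound 1 the nearest, at a distance beyond the scatter. Within the data shown here, the single measured step, a 2.4-fold higher number from compound 1 to compound 2 (0.38 log units; beyond the scatter), came from putting 1-hydroxycyclohexyl in place of 1-hydroxyethyl on an aromatic carbon. Compound 3 `CC(OCCO)c1cn(CCNc2nonc2/C(=N/O)Nc2ccc(F)c(Br)c2)nn1` differs from compound 2 in the following way: 1-(2-hydroxyethoxy)ethyl in place of 1-hydroxycyclohexyl on an aromatic carbon. This change undoes the ring that the step from compound 1 to compound 2 had introduced and keeps an open chain carrying a hydroxyl, so that step is the only one that bears on it. On that basis compound 3 is expected to move back toward compound 1, with a 1.9-fold lower number from compound 2 to compound 3 (0.28 log units; within the scatter) estimated as the likely step in this assay. The estimated value for compound 3 is 450 nM, with a range from 200 nM to 1000 nM.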

Compound 3, half-maximal inhibitory concentration: 930 nM
For compound 3 the middle estimate is 2.1-fold (0.32 log units) below the measured one; measured number inside the range.
By their numbers in this assay, from the lowest: compound 1; then compounds 2 and 3 (each within the scatter of the next).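

In this assay, removing the ring does not by itself bring the number back toward that of compound 1: the open chain 1-(2-hydroxyethoxy)ethyl in place of 1-hydroxycyclohexyl gives a 1.1-fold higher number from compound 2 to compound 3 (0.03 log units; within the scatter) and so cannot be told apart from the ring-bearing group on this read-out. Adding 2-hydroxyethyl to the oxygen of compound 1 gives a 2.6-fold higher number from compound 1 to compound 3 (0.41 log units; beyond the scatter) and so, at this aromatic carbon, both larger groups stand apart from 1-hydroxyethyl, with or without a ring. No measurement at hand explains these numbers.

On these data alone, it remains open whether an amine or a carboxylic acid on the same aromatic carbon would sit with compound 1 or with compound 2 and compound 3. Also open, as far as these compounds go, is how a methyl ether in place of the terminal hydroxyl of the open chain would read.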